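A few compounds are considered here, and "the series" means these few. Any claim that something is new, unique, unknown or untested is made for them only; others in the source may bear on it.

Three compounds share one core and differ only in the aryl group attached to it. Compound 1 `Cc1cc(-c2cc(Cl)cc(Cl)c2)cc(C)c1Nc1ccnc(Nc2ccc(C#N)cc2)n1` bears a 3,5-dichlorophenyl, compound 2 `COc1ccc(-c2cc(C)c(Nc3ccnc(Nc4ccc(C#N)cc4)n3)c(C)c2)cc1` a 4-methoxyphenyl, and compound 3 `Cc1cc(-c2cccc(Cl)c2)cc(C)c1Nc1ccnc(Nc2ccc(C#N)cc2)n1` a 3-chlorophenyl. In an ADME assay on MT4 cells (Homo sapiens) for cytotoxicity, read by MTT assay, with a stated time of 4 days (on this read-out higher numbers stand for lower toxicity in this test and lower numbers for higher toxicity in this test), compound 1 gives 4290 nM, compound 2 gives 2890 nM, and compound 3 gives 2160 nM. Compound 2 sits in the middle of the three numbers: its nearest neighbour is compound 3, reached by a 1.3-fold lower number from compound 2 to compound 3 (0.13 log units; within the scatter), and its furthest is compound 1, separated by a 1.5-fold lower number from compound 1 to compound 2 (0.17 log units; within the scatter); the remaining pair shows a 2.0-fold lower number from compound 1 to compound 3 (0.30 log units; within the scatter).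

Compound 4 `Cc1cc(-c2ccccc2Cl)cc(C)c1Nc1ccnc(Nc2ccc(C#N)cc2)n1` has not yet been tested. Relative to compound 2 the change is 2-chlorophenyl in place of 4-methoxyphenyl on an aromatic carbon. Within the data shown here, the steps that bear on it are the methoxyphenyl-to-chlorophenyl exchange, a 1.3-fold lower number from compound 2 to compound 3 (0.13 log units; within the scatter), and the removal of a chloro, a 2.0-fold lower number from compound 1 to compound 3 (0.30 log units; within the scatter), both within the scatter. No step beyond the scatter is therefore expected in this assay, in either direction. Compound 4 is expected to give 2800 nM, between 1200 nM and 6500 nM, that is an estimated 1.0-fold lower number from compound 2 to compound 4 (0.01 log units; within the scatter).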

Compound 4, half-maximal cytotoxic concentration: 3990 nM
Estimate against measurement, compound 4: 1.4-fold (0.15 log units) below, and the stated range covers the measured number.
By their numbers in this assay, from the lowest: compounds 3, 2, 4 and 1 (each within the scatter of the next).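

At the aryl position of the shared core, exchanging 4-methoxyphenyl for 2-chlorophenyl gives a 1.4-fold higher number from compound 2 to compound 4 (0.14 log units; within the scatter) in this assay and so does not take the number beyond the scatter. Moving the chloro to its place in the 2-chlorophenyl group gives a 1.8-fold higher number from compound 3 to compound 4 (0.27 log units; within the scatter) as its step, and the exchange of the 3,5-dichlorophenyl group for 2-chlorophenyl gives a 1.1-fold lower number from compound 1 to compound 4 (0.03 log units; within the scatter) as its step, so neither the place of the chloro nor the presence of a second chloro separates these compounds in this test. Nothing measured here bears on the reason for this picture. 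

From the compounds shown here alone, whether an amine or a carboxylic acid on this aryl ring would produce a step beyond the scatter remains open. The same holds for a longer alkyl chain in place of the aryl group.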